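A Para Substituent Swap on the Benzylamine Arm

The source may hold more compounds than are shown below. What is called first, only, known or untested is meant among the compounds shown, and "the series" means these compounds.

Within the data shown here, compound 2 `COc1ccc(CNc2nc(NCc3ccccc3)c3ccccc3n2)cc1` is one of two compounds measured in an ADME assay on J774.A1 cells (Mus musculus) for inhibition, read by MTT assay, with a stated time of 72 h; on this read-out lower numbers stand for an effect already at smaller amounts and higher numbers for an effect only at larger amounts of compound. Among the measured compounds shown here, there compound 2 gives 4100 nM, the smaller of the two numbers, though its only neighbour, compound 1 `Cc1ccc(CNc2nc(NCc3ccccc3)c3ccccc3n2)cc1`, gives 4500 nM and the two lie within the scatter of each other. For the measured compounds named here, the single step on record, a 1.1-fold lower number from compound 1 to compound 2 (0.04 log units; within the scatter), stays within the scatter.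

Compound 3 `Clc1ccc(CNc2nc(NCc3ccccc3)c3ccccc3n2)cc1` is not yet measured. Relative to compound 2 it differs thus: chloro in place of methoxy on an aromatic carbon. Going by the values given here, the one measured step also concerns a group on an aromatic carbon, but it exchanges two other groups, so it is the only guide, and it was flat. Compound 3 is therefore expected to show no step beyond the scatter in this assay, with a 1.0-fold lower number from compound 2 to compound 3 (0.01 log units; within the scatter) as the estimated change. On that basis compound 3 is estimated at 4000 nM, in the range from 2000 nM to 8000 nM.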

Compound 3, half-maximal effective concentration: 3200 nM
Estimate against measurement, compound 3: 1.3-fold (0.10 log units) above, within the range that was stated.
By their numbers in this assay, from the lowest: compounds 3, 2 and 1 (each within the scatter of the next).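

In this assay, the third group at this place, on an aromatic carbon para to a large group, still opens no gap: chloro in place of methoxy gives a 1.3-fold lower number from compound 2 to compound 3 (0.11 log units; within the scatter) and chloro in place of methyl gives a 1.4-fold lower number from compound 1 to compound 3 (0.15 log units; within the scatter). The earlier pair compared only methyl and methoxy, whereas chloro brings a single chlorine atom and, unlike methoxy, no hydrogen-bond acceptor. All three compounds now lie within the scatter of one another, so none of these three groups stands apart in this assay. Nothing shown here explains these numbers.

The compounds shown leave open whether an amine, a carboxylic acid or a longer chain at this place would produce a step beyond the scatter. They also leave open whether changes elsewhere on the shared core would behave the same way.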